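From methylsulfanyl to trifluoromethyl on the shared core

The compounds below may be only part of what the source reports. "The series", "measured", "known", "first", "only" and "open" are said of these compounds alone.

Measured in a functional assay on HCT-116 cells (Homo sapiens) for antiproliferative activity, read by MTT assay, with a stated time of 72 h; a lower number here means a stronger inhibitor, a higher number a weaker inhibitor:
Compound 1 `O=C(CCc1cccc2c1B(O)OC2)Nc1cccc(-c2ccc(F)cc2)c1`: 550 nM
Compound 2 `O=C(CCc1cccc2c1B(O)OC2)Nc1cccc(-c2ccc(OC(F)(F)F)cc2)c1`: 730 nM
Compound 3 `CSc1ccc(-c2cccc(NC(=O)CCc3cccc4c3B(O)OC4)c2)cc1`: 180 nM

Compound 3 holds the lowest of these numbers. Compound 4 `O=C(CCc1cccc2c1B(O)OC2)Nc1cccc(-c2ccc(C(F)(F)F)cc2)c1` carries trifluoromethyl in place of methylsulfanyl on an aromatic carbon, para to a large group (trifluoromethyl in place of methylsulfanyl on an aromatic carbon). Going by the values given here, no measured step makes this exact change, but three bear on it. Moving to methylsulfanyl gave a 3.1-fold lower number from compound 1 to compound 3 (0.49 log units; beyond the scatter) and a 4.1-fold lower number from compound 2 to compound 3 (0.61 log units; beyond the scatter), both modest, while a 1.3-fold higher number from compound 1 to compound 2 (0.12 log units; within the scatter) stayed within the scatter. Leaving methylsulfanyl is therefore expected to give a modest step to a higher number in this assay, estimated as a 3.3-fold higher number from compound 3 to compound 4 (0.52 log units; beyond the scatter). Compound 4 is estimated at 600 nM, with an expected range from 270 nM to 1300 nM.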

Compound 4, half-maximal inhibitory concentration: 550 nM
Compound 4: the middle estimate sits 1.1-fold (0.04 log units) above what was measured; low and high end bracket the measured number.
By their numbers in this assay, from the lowest: compound 3; then compounds 1, 4 and 2 (each within the scatter of the next).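

In this assay, trifluoromethyl is a third group at this position that stays apart from methylsulfanyl, with a 3.1-fold higher number from compound 3 to compound 4 (0.49 log units; beyond the scatter). The three groups without sulfur now form a level set, with a 1.3-fold lower number from compound 2 to compound 4 (0.12 log units; within the scatter) and no change at the digits printed from compound 1 to compound 4 (within the scatter), so among these four compounds only methylsulfanyl stands apart. Nothing measured here accounts for that difference.

Going by these compounds, whether methoxy, an amine or a longer sulfur-bearing chain such as ethylsulfanyl would group with methylsulfanyl or with the other three stays open, as does whether the gap would persist on a different core.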